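A Larger Ring Group on an Inactive Compound

The source may hold more compounds than are shown below. What is called first, only, known or untested is meant among the compounds shown, and "the series" means these compounds.

In a functional assay on K562 cells (Homo sapiens), read by MTT assay, with a stated time of 72 h (on this read-out lower numbers stand for stronger inhibition and higher numbers for weaker inhibition), compound 3 (`CNc1ncnc2c1c(-c1ccoc1)cn2[C@@H]1O[C@H](CO)[C@@H](O)[C@H]1O`) gives > 20000 nM, which is a limit and not a number. It therefore stands at the limit of > 20000 nM in this assay, at which 1 of the 3 values shown sits. Compound 1 (`CSc1ncnc2c1c(-c1ccoc1)cn2[C@@H]1O[C@H](CO)[C@@H](O)[C@H]1O`) gives 60 nM. Compound 2 (`C#Cc1cn([C@@H]2O[C@H](CO)[C@@H](O)[C@H]2O)c2ncnc(SC)c12`) gives 30 nM.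

The next compound, compound 4 (`CNc1ncnc2c1c(-c1cc3ccccc3o1)cn2[C@@H]1O[C@H](CO)[C@@H](O)[C@H]1O`), keeps the methylamino group of compound 3 and changes a different group: 1-benzofuran-2-yl in place of furan-3-yl on an aromatic carbon. In words, 1-benzofuran-2-yl stands in place of furan-3-yl on an aromatic carbon.

For the measured compounds named here, two measured steps bear on this change. Exchanging furan-3-yl for ethynyl at that same carbon gave a 2.0-fold lower number from compound 1 to compound 2 (0.30 log units; within the scatter), so that exchange made no difference beyond the scatter. However, that step was measured with methylsulfanyl in the molecule, and 1-benzofuran-2-yl itself has not been tested. Exchanging methylsulfanyl for methylamino gave an at least 330-fold higher number from compound 1 to compound 3 (2.52 log units; beyond the scatter), by far the larger effect. On these two steps, the methylamino group seems to matter more than the group on the aromatic carbon, so no clear recovery of activity is expected in this assay.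

The expected change is a number no higher from compound 3 to compound 4 (the limit leaves the size open), and a reading that again gives only a limit is quite likely. For compound 4 the estimated value is 20000 nM, with an expected range from 6000 nM to 40000 nM.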

Compound 4, half-maximal inhibitory concentration: > 20000 nM
Compound 4 ended at the assay's limit; the forecaster's own chance of this, stated with the estimate: 70%; the middle value sits exactly at the limit.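

In this assay, compound 3 and compound 4 both sit at a limit and not at a number, so no new step can be read between them: the limit of > 20000 nM in this assay, at which 2 of the 4 values shown sit.

The compounds shown leave open whether 1-benzofuran-2-yl in place of furan-3-yl would change the result with methylsulfanyl in the molecule, as in compound 1.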